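The compounds below may be only part of what the source reports. "The series", "measured", "known", "first", "only" and "open" are said of these compounds alone.

Measured compounds:
Compound 1, `COc1c(OCCCCN2CCN(C)CC2)cc(O)c2c(=O)cc(-c3ccc(C(F)(F)F)cc3)oc12`, gives 2890 nM in a functional assay on A549 cells (Homo sapiens) for cytotoxicity, read by MTT assay, with a stated time of 72 h; a higher number here means a weaker inhibitor, a lower number a stronger inhibitor.
Compound 2, `CN(C)CCCOc1c(OCc2ccccc2)cc(O)c2c(=O)cc(-c3ccccc3)oc12`, gives 2910 nM in this assay.
Compound 3, `CN1CCN(CCCOc2c(OCc3ccccc3)cc(O)c3c(=O)cc(-c4ccccc4)oc23)CC1`, gives 3940 nM in this assay.

All three values lie within the scatter of one another, so compound 3 cannot be set apart from compound 1 or compound 2 on these numbers. Compound 4, `O=c1cc(-c2ccccc2)oc2c(OCCCCN3CCCC3)c(OCc3ccccc3)cc(O)c12`, has not yet been measured; it differs from compound 3 by (pyrrolidin-1-yl)methyl in place of 4-methylpiperazin-1-yl on a saturated chain carbon, three bonds along the chain from an oxygen on an aromatic ring. Among the measured compounds shown here, the only measured step that touches this end of the chain is a 1.4-fold higher number from compound 2 to compound 3 (0.13 log units; within the scatter), where one amine terminus replaced another at the same place and the number stayed within the scatter. For the measured compounds named here, compound 1 and compound 2 differ in more than one place, so no single step can be drawn from that pair. On this evidence the exchange to the pyrrolidin-1-yl terminus is expected to leave the number close to that of compound 3, with a 1.1-fold lower number from compound 3 to compound 4 (0.05 log units; within the scatter) expected to fall within the scatter. Compound 4 is therefore estimated at 3500 nM in this assay, with a range from 1500 nM to 8000 nM.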

Compound 4, half-maximal inhibitory concentration: 1100 nM
Compound 4: the middle estimate sits 3.2-fold (0.50 log units) above what was measured; the whole stated range lies above it.
By their numbers in this assay, from the lowest: compound 4; then compounds 1, 2 and 3 (each within the scatter of the next).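

In this assay, the amine end of this chain proved able to move the number beyond the scatter, with a 3.6-fold lower number from compound 3 to compound 4 (0.55 log units; beyond the scatter) and a 2.6-fold lower number from compound 2 to compound 4 (0.42 log units; beyond the scatter), whereas the earlier exchange of one amine terminus for another, a 1.4-fold higher number from compound 2 to compound 3 (0.13 log units; within the scatter), stayed within it. Cut one bond further out, the change from compound 3 reads 3-(4-methylpiperazin-1-yl)propyl to 4-(pyrrolidin-1-yl)butyl, so the ring and the chain length change together and the values cannot divide the step between them. Nothing available accounts for these steps.

On these data alone, it remains open whether 3-(pyrrolidin-1-yl)propyl on the core of compound 4 would keep the lower number, or whether 4-(4-methylpiperazin-1-yl)butyl there would reach it. As far as these compounds go, how a piperidine or morpholine terminus, or a still longer chain, would read in this assay is also open.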